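Flavonoid glycoside series: stereochemically undefined analogue of compound 1

The compounds below may be only part of what the source reports. "The series", "measured", "known", "first", "only" and "open" are said of these compounds alone.

Measured so far:
Compound 1 `COc1ccc(-c2cc(=O)c3c(O)c(OC)c(O[C@@H]4O[C@H](CO[C@@H]5O[C@@H](C)[C@H](O)[C@@H](OC(C)=O)[C@H]5O)[C@@H](O)[C@H](O)[C@H]4O)cc3o2)cc1` gives > 54500 nM in a functional assay on MRC5 cells (Homo sapiens) for inhibition, in the presence of a further agent that is not named here; a higher number here means a weaker inhibitor, a lower number a stronger inhibitor; this value is a limit of the assay, not a number.
Compound 2 `COC1=C(O)C2=C(O)C=C(c3ccc(OC)cc3)OC2=CC1OC1OC(O)C(O)C(O)C1O` gives > 101000 nM in this assay; this value too is a limit.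

Among the measured compounds shown here, compound 1 therefore stands only at a limit, and the one further value shown is likewise a limit (the limit of > 101000 nM in this assay, at which 1 of the 2 values shown sits), so no ordering of the two compounds can be drawn. For the measured compounds named here, no step between measured compounds is available.

Compound 3 `COc1ccc(-c2cc(=O)c3c(O)c(OC)c(O[C@@H]4OC(CO[C@@H]5OC(C)[C@H](O)[C@H](OC(C)=O)C5O)[C@@H](O)[C@H](O)C4O)cc3o2)cc1` is to be measured in this assay. Its difference from compound 1 is the two compounds have the same atoms and bonds; at least one stereo element is drawn with a configuration in one of them and without one in the other: 5 of 10 stereo elements differ; a stereocentre at a saturated ring carbon is drawn R in compound 1 and without a configuration in compound 3; a stereocentre at a saturated ring carbon is drawn S in compound 1 and without a configuration in compound 3; a stereocentre at a saturated ring carbon is drawn R in compound 1 and S in compound 3; a stereocentre at a saturated ring carbon is drawn R in compound 1 and without a configuration in compound 3. The atoms and bonds are unchanged; only the drawn configurations differ. No change beyond the scatter is expected from compound 1 to compound 3, so the step that the limit leaves unreadable from compound 1 to compound 3 is estimated as essentially flat, most likely again returning only a limit (the limit of > 54500 nM in this assay, at which 1 of the 2 values shown sits).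

The estimate for compound 3 in this assay is 60000 nM, with a range from 25000 nM to 200000 nM.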

Compound 3, half-maximal inhibitory concentration: > 75300 nM
Compound 3 ended at the assay's limit; the forecaster's own chance of this, stated with the estimate: 85%; at least 1.2-fold (0.09 log units) between middle value and limit.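

Compound 3 gives > 75300 nM in this assay, and this value is a limit. Among the compounds shown here, compound 1 also stands at a limit, so no step from compound 1 to compound 3 can be read. The compounds shown leave open whether the drawn configuration affects inhibition in this assay.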